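Removing the Methyl Group: From Compound 3 to Compound 4

A few compounds are considered here, and "the series" means these few. Any claim that something is new, unique, unknown or untested is made for them only; others in the source may bear on it.

Compound 1, `CCCCCc1cc2nn(-c3ccccc3)cc2cn1`, gives 11800 nM in a functional assay on MCF7 cells (Homo sapiens) for inhibition, read by fluorescence, with a stated time of 72 h; a lower number here means a stronger inhibitor of growth, a higher number a weaker inhibitor of growth.
Compound 2, `Cc1nc(-c2ccccc2)cc2nn(-c3ccccc3)cc12`, gives 11000 nM in this assay.
Compound 3, `Cc1nc(-c2ccsc2)cc2nn(-c3ccccc3)cc12`, gives 22200 nM in this assay.

Compound 3 gives the largest of the three numbers, yet its gaps to compound 1 and to compound 2 both lie within the usual scatter, so the three compounds cannot be told apart on these data.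

Compound 4, `c1ccc(-n2cc3cnc(-c4ccsc4)cc3n2)cc1`, is not yet measured. It differs from compound 3 in one place: hydrogen in place of methyl on an aromatic carbon. Among the compounds with values here, the only measured single-point step is a 2.0-fold higher number from compound 2 to compound 3 (0.30 log units; within the scatter), and it concerns the thiophen-3-yl group, not the methyl. Within the data shown here, no measured pair shows what taking away this methyl does; compound 1 also lacks it, but carries a pentyl chain instead, so it gives no clean comparison. With nothing pointing either way, the expectation is no step beyond the scatter in this assay.

Compound 4 is therefore estimated at 22000 nM, with a likely range from 8000 nM to 60000 nM, which means an expected step of a 1.0-fold lower number from compound 3 to compound 4 (0.00 log units; within the scatter).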

Compound 4, concentration for 50% growth inhibition: 9800 nM
Compound 4: the middle estimate sits 2.2-fold (0.35 log units) above what was measured, within the range that was stated.
By their numbers in this assay, from the lowest: compounds 4, 2, 1 and 3 (each within the scatter of the next, the first and the last beyond it).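

Hydrogen in place of methyl on this aromatic carbon, next to the ring nitrogen, gives a 2.3-fold lower number from compound 3 to compound 4 (0.36 log units; beyond the scatter) in this assay, the first single-place step in the series to lie beyond the scatter, which shows that this position can register a change, although the step is modest. With the methyl absent from both compounds, thiophen-3-yl in place of pentyl gives a 1.2-fold lower number from compound 1 to compound 4 (0.08 log units; within the scatter), so in this setting these two very different groups cannot be told apart on growth inhibition. Nothing measured here explains why the step at the methyl position has this direction or size.

Going by these compounds, one methyl-to-hydrogen pair cannot show whether the same step would appear with phenyl in place of thiophen-3-yl, so it remains unknown whether the effect depends on the neighbouring group. On these data alone, it is also open how this carbon would respond to other groups, such as an ethyl chain, a methoxy group or an amine, and whether any of them would move the number further in either direction.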